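The compounds below may be only part of what the source reports. "The series", "measured", "known", "first", "only" and "open" are said of these compounds alone.

Measured so far in an ADME assay on HS27 cells (Homo sapiens) for antiproliferative activity, read by MTT assay, with a stated time of 24 h; a lower number here means a stronger inhibitor, a higher number a weaker inhibitor:
compound 1 `O=C(Nc1ccc(-n2ccc3c(NC(=O)c4ccccc4)ncnc32)cc1)c1ccc(Cl)c(C(F)(F)F)c1`: 5500 nM
compound 2 `Cc1cn(-c2cc(C(=O)Nc3ccc(-n4ccc5c(NC(=O)c6ccccc6)ncnc54)cc3)cc(C(F)(F)F)c2)cn1`: 2800 nM
compound 3 `O=C(Nc1ccc(-n2ccc3c(NC(=O)c4ccccc4)ncnc32)cc1)Nc1cc(C(F)(F)F)cc(C(F)(F)F)c1`: > 10000 nM

Compound 2 holds the lowest of the two numbers shown, with compound 1 within the scatter of it. Compound 3 reaches only a limit of the assay (the limit of > 10000 nM in this assay, at which 1 of the 3 values shown sits), not a number. Compound 4 `O=C(Nc1ccc(-n2ccc3c(NC(=O)c4ccccc4)ncnc32)cc1)c1cc(C(F)(F)F)cc(C(F)(F)F)c1` is not yet measured. Against compound 2 the change is trifluoromethyl in place of 4-methyl-1H-imidazol-1-yl on an aromatic carbon. Among the measured compounds shown here, no step between measured compounds covers such a change, so its size in this assay is not known from the data; a move toward a higher number of modest size is expected, since compound 1, also carrying a trifluoromethyl on that ring, gives 5500 nM. Compound 4 is expected to give 5000 nM, with a range of 2000 nM to 12000 nM. The expected step is a 1.8-fold higher number from compound 2 to compound 4 (0.25 log units; within the scatter).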

Compound 4, half-maximal inhibitory concentration: 6600 nM
Compound 4: the middle estimate sits 1.3-fold (0.12 log units) below what was measured; the measured number falls inside the stated range.
By their numbers in this assay, from the lowest: compounds 2, 1 and 4 (each within the scatter of the next, the first and the last beyond it). At a limit, above all of these: compound 3.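

In this assay trifluoromethyl in place of 4-methyl-1H-imidazol-1-yl gives a 2.4-fold higher number from compound 2 to compound 4 (0.37 log units; beyond the scatter) as the first step read at this position, so the group there does move the number, though only modestly. Compound 4 still gives a number, so this change alone does not carry the series to a limit. Compound 3 alone stands at a limit, not a number: the limit of > 10000 nM in this assay, at which 1 of the 4 values shown sits.

Still open, from the compounds shown here alone, is where an amine or a carboxylic acid at this position would fall relative to these two groups. Which feature of 4-methyl-1H-imidazol-1-yl accounts for the step also remains unsettled.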